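The compounds below may be only part of what the source reports. "The series", "measured", "known", "first", "only" and "open" are said of these compounds alone.

Measured so far:
Compound 1 `O=C(Nc1ccc(Sc2nc3ccccc3s2)cc1)c1cc(Br)cc(Br)c1O`: 20000 nM
Compound 2 `O=S(=O)(Nc1ccc(-c2nc3cc(NS(=O)(=O)c4ccccc4Cl)ccc3o2)cc1)c1ccccc1Cl`: 17000 nM
Compound 3 `Cc1ccc(S(=O)(=O)Nc2ccc(-c3nc4ccc(NS(=O)(=O)c5ccc(C)cc5)cc4[nH]3)cc2)cc1`: 25000 nM

In a functional assay on DLD-1 cells (Homo sapiens) for cytotoxicity, read by resazurin assay, with a stated time of 48 h (a lower number here means that less compound is needed, a higher number that more compound is needed for the effect), compound 1 gives 20000 nM, compound 2 gives 17000 nM and compound 3 gives 25000 nM. Compound 1 holds the second highest of these three numbers, yet its gaps to compound 2 and to compound 3 both lie within the usual scatter, so the three cannot be told apart on these data.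

Compound 4 `COc1c(Br)cccc1C(=O)Nc1ccc(Sc2nc3ccccc3s2)cc1` keeps the core of compound 1 and changes one group on the carbonyl carbon: a group of 9 heavy atoms (7 carbon, 1 oxygen, 1 bromine; one six-membered aromatic ring of carbon only) in place of a group of 9 heavy atoms (6 carbon, 1 oxygen, 2 bromine; one six-membered aromatic ring of carbon only), on a carbonyl carbon. Among the measured compounds shown here, no step between measured compounds shows what a change of this kind does here, so the expectation rests on compound 1 alone. The step of a 1.5-fold higher number from compound 1 to compound 4 (0.18 log units; within the scatter) is expected to be modest, if anything toward a higher number, and may well stay within the scatter. Compound 4 is estimated at 30000 nM, with a range from 12000 nM to 80000 nM.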

Compound 4, half-maximal effective concentration: 40000 nM
Compound 4: the middle estimate sits 1.3-fold (0.12 log units) below what was measured; measured number inside the range.
By their numbers in this assay, from the lowest: compounds 2, 1, 3 and 4 (each within the scatter of the next, the first and the last beyond it).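

Among the compounds shown here, this is the first step at the group on the carbonyl carbon: in this assay, replacing 3,5-dibromo-2-hydroxyphenyl with a group carrying one bromine and no hydrogen-bond donor gives a 2.0-fold higher number from compound 1 to compound 4 (0.30 log units; within the scatter) and so shows no clear effect at this place. No measurement shown explains this result.

On these data alone, the bromine count and the donor count change together here, and their separate contributions remain unknown. As far as these compounds go, whether a carboxylic acid or an amine on the ring of this group would shift the number also remains open.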